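The source may report more compounds than this note shows. Statements on the series, on what has been measured and on what is new or still open speak of the compounds shown alone.

Working notes on the hydrazone series against an assay on isolated protein for inhibition of Amine oxidase [flavin-containing] B (Homo sapiens), read by spectrophotometry; on this read-out higher numbers stand for weaker inhibition and lower numbers for stronger inhibition.

Within the data shown here, compound 1 `C(=N/Nc1nc2ccccc2nc1Cc1ccccc1)\c1ccccc1` gives 320000 nM in this assay and stands lowest of the three numbers measured so far. Compound 3 `C/C(=N\Nc1nc2ccccc2nc1Cc1ccccc1)c1ccc(N)cc1` gives 860000 nM, the nearest of the others, and compound 2 `C/C(=N\Nc1nc2ccccc2nc1Cc1ccccc1)c1ccc(O)cc1` gives 8400000 nM, the furthest. Among the measured compounds shown here, the only step within the set that changes a single group is a 9.8-fold lower number from compound 2 to compound 3 (0.99 log units; beyond the scatter), which concerns the group on the phenyl of the methyl-bearing hydrazones and not the change considered here.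

Compound 4 `Brc1cccc(/C=N/Nc2nc3ccccc3nc2Cc2ccccc2)c1` differs from compound 1 only as bromo in place of hydrogen on an aromatic carbon. For the measured compounds named here, no measured step in this assay bears on that change: nothing shows what a halogen on this phenyl does to the read-out, and the step from compound 2 to compound 3 cannot be carried over. The expectation for compound 4 is therefore a step of a 1.3-fold lower number from compound 1 to compound 4 (0.11 log units; within the scatter) from compound 1, within or near the scatter, with no direction well supported by the data. Compound 4 is estimated at 250000 nM in this assay, ranging from 70000 nM to 900000 nM.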

Compound 4, half-maximal inhibitory concentration: 48000 nM
Compound 4: the middle estimate sits 5.2-fold (0.72 log units) above what was measured; measured number below the stated range.
By their numbers in this assay, from the lowest: compound 4; then compound 1; then compound 3; then compound 2.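

In this assay, the change from phenyl to 3-bromophenyl gives a 6.7-fold lower number from compound 1 to compound 4 (0.82 log units; beyond the scatter) and so shows that this aromatic carbon, meta to a large group, is not indifferent to substitution. Among these compounds, this is the first measured change on the phenyl of compound 1 and the first halogen in the set, and it leaves compound 4 with the lowest number of the four. No measurement shown gives a reason for this step.

On these data alone, whether the step is particular to bromo or would also appear with chloro, fluoro or methyl at the same carbon remains open, as does the effect of bromo on other carbons of this ring. The compounds shown also do not tell whether bromo would bring a similar step to the methyl-bearing hydrazones, compound 2 and compound 3.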